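A Smaller Group on the Aryl Ether Carbon

This account rests on a few compounds, and the source may have more. Where it says the series, first, only, none or still open, it means among the compounds named here.

For the measured compounds named here, compound 2 `O=C1CC(c2ccccc2OCc2cccc(F)c2)Oc2ccccc21` stands highest of the two numbers measured so far in a functional assay on RAW264.7 cells (Mus musculus) for inhibition, read by immunoassay, with a stated time of 12 h, tested at 30 uM (on this read-out lower numbers stand for less inhibition and higher numbers for more inhibition at the one concentration tested (going by the name of the read-out)), where compound 2 gives 93.3%. Its nearest measured neighbour is compound 1 `COc1ccccc1C1CC(=O)c2ccccc2O1`, which carries only hydrogen on the saturated chain carbon bound to an oxygen on an aromatic ring; in this assay compound 1 gives 37.3%. Going by the values given here, the single measured step, a number 56 percentage points higher from compound 1 to compound 2 (beyond the scatter), shows that what sits on this carbon makes a large difference in this assay. Compound 3 `COCOc1ccccc1C1CC(=O)c2ccccc2O1` has not yet been measured. Its change from compound 2 is methoxy in place of 3-fluorophenyl on a saturated chain carbon bound to an oxygen on an aromatic ring. The methoxy that enters is a smaller group than the 3-fluorophenyl that leaves, so much of the gain seen in that step is expected to be given back, though compound 3 still carries more than the bare hydrogen of compound 1. The expected step is therefore a fall, a number 43.3 percentage points lower from compound 2 to compound 3 (beyond the scatter). Compound 3 is expected to give 50%, with a likely range from 25% to 80%.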

Compound 3, a percentage reported as inhibition, at one concentration (the size of the read-out at that concentration, not a potency): 35.2%
Compound 3: the middle estimate sits 14.8 percentage points above what was measured; the measured number falls inside the stated range.
By their numbers in this assay, from the lowest: compounds 3 and 1 (each within the scatter of the next); then compound 2.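

In this assay, putting methoxy in place of 3-fluorophenyl on this carbon gives a number 58.1 percentage points lower from compound 2 to compound 3 (beyond the scatter) and so takes away the whole gain seen earlier, as the step from hydrogen reads a number 2.1 percentage points lower from compound 1 to compound 3 (within the scatter) and leaves those two compounds level. A group on this saturated chain carbon therefore does not lift the number merely by being there: methoxy, with 2 heavy atoms and no ring, counts for no more than hydrogen, and of the three compounds only compound 2, with its 3-fluorophenyl, stands high. Nothing measured here gives a reason for this. 

The compounds shown cannot separate the part played by the ring from that of its fluorine, as none carries a plain phenyl on this carbon. Going by these compounds, whether a ringless group larger than methoxy, such as a butyl chain, could also raise the number stays open too.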